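A few compounds are considered here, and "the series" means these few. Any claim that something is new, unique, unknown or untested is made for them only; others in the source may bear on it.

So far two compounds built on a shared core have been measured. In a physicochemical assay for lipophilicity, read by HPLC, in phosphate buffer, measured as octanol-water partition, with a stated time of 1 h, at pH 7.4 (on this read-out higher numbers stand for higher lipophilicity and lower numbers for lower lipophilicity), compound 1 `C[C@@]1(c2cc(NC(=O)c3cnc(OCF)cn3)ccc2F)C=C(CF)OC(N)=N1` gives 2.6, and compound 2 `C[C@@]1(c2cc(NC(=O)c3coc(C(F)F)n3)ccc2F)C=C(CF)OC(N)=N1` gives 2.6, which leaves compound 2 level with compound 1. Compound 3 `C[C@@]1(c2cc(NC(=O)c3cnc(C(F)F)cn3)ccc2F)C=C(CF)OC(N)=N1` has not yet been measured. It carries 5-(difluoromethyl)pyrazin-2-yl in place of 2-(difluoromethyl)-1,3-oxazol-4-yl on a carbonyl carbon. Going by the values given here, only one measured step bears on this change. It alters the group at the same place: 2-(difluoromethyl)-1,3-oxazol-4-yl replaced 5-(fluoromethoxy)pyrazin-2-yl there, and the result was no change at the digits printed from compound 1 to compound 2 (within the scatter). A single step is thin evidence, so the range has to stay fairly wide. In this assay the expected result is no change at the digits printed from compound 2 to compound 3 (within the scatter), with neither direction favoured. For compound 3 the estimated value is 2.6, with an expected range from 2.2 to 3.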

Compound 3, distribution coefficient: 2.5
Compound 3: middle estimate off by 0.10 log units, on the high side; low and high end bracket the measured number.
By their numbers in this assay, from the lowest: compounds 3, 1 and 2 (each within the scatter of the next).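

In this assay, changing the ring that carries the difluoromethyl group gives a number 0.10 log units lower from compound 2 to compound 3 (within the scatter), so 5-(difluoromethyl)pyrazin-2-yl and 2-(difluoromethyl)-1,3-oxazol-4-yl cannot be told apart on this read-out when attached to a carbonyl carbon whose other neighbour is an amide-type nitrogen. With the ring kept, difluoromethyl in place of fluoromethoxy on an aromatic carbon gives a number 0.10 log units lower from compound 1 to compound 3 (within the scatter), which isolates a change that the earlier step had mixed with a change of ring. Nothing measured here accounts for either result.

All the groups compared at this place carry fluorine. An amine, a carboxylic acid or a plain methyl group in place of difluoromethyl would show whether this read-out can move beyond the scatter through changes at this position.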